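A third bromophenyl variant of an inactive series

The source may report more compounds than this note shows. Statements on the series, on what has been measured and on what is new or still open speak of the compounds shown alone.

Compound 1 `N#CC1=C(N)Oc2c(c3nc4ccccc4nc3c3ccccc23)C12C(=O)N(Cc1cnnn1-c1ccc(F)cc1)c1ccccc12` was examined in a functional assay on HCT-116 cells (Homo sapiens) for antiproliferative activity, read by MTT assay, with a stated time of 48 h; on this read-out lower numbers stand for stronger inhibition and higher numbers for weaker inhibition. In this assay compound 1 gives > 50000 nM, which is a limit of the assay and not a measured number. Compound 2 `N#CC1=C(N)Oc2c(c3nc4ccccc4nc3c3ccccc23)C12C(=O)N(Cc1cnnn1-c1ccc(Br)cc1)c1ccccc12` carries bromo in place of fluoro on an aromatic carbon; in this assay compound 2 gives > 50000 nM, again a limit. Compound 3 `N#CC1=C(N)Oc2c(c3nc4ccccc4nc3c3ccccc23)C12C(=O)N(Cc1cnnn1-c1ccccc1Br)c1ccccc12` carries 2-bromophenyl in place of 4-fluorophenyl on an aromatic nitrogen; in this assay compound 3 gives > 50000 nM, also a limit. Because every value shown sits at the limit of > 50000 nM in this assay, at which 3 of the 3 values shown sit, none of the steps between these compounds can be sized: a step that the two limits leave unreadable from compound 1 to compound 2, a step that the two limits leave unreadable from compound 1 to compound 3 and a step that the two limits leave unreadable from compound 2 to compound 3 all remain unreadable.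

Compound 4 `N#CC1=C(N)Oc2c(c3nc4ccccc4nc3c3ccccc23)C12C(=O)N(Cc1cnnn1-c1cccc(Br)c1)c1ccccc12` has not yet been measured. It differs from compound 1 in one place: 3-bromophenyl in place of 4-fluorophenyl on an aromatic nitrogen. The two measured changes at this same place, a bromine for the fluorine and a move of the bromine to another position of the phenyl ring, both left the compound at the limit, so nothing measured here points to a gain in potency from a bromophenyl group.

Compound 4 is therefore expected to stay at the limit as well, with an estimate of 80000 nM and a range from 30000 nM to 300000 nM. The expected step that the limit leaves unreadable from compound 1 to compound 4 is no readable change from the limit.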

Compound 4, half-maximal inhibitory concentration: > 50000 nM
Compound 4 gave a limit, no number; the forecaster's own chance of this, stated with the estimate: 85%; the middle value is on the limit's open side.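

In this assay compound 4 gives > 50000 nM, which is a limit and not a measured number. No step between compound 4 and compound 1, compound 2 or compound 3 can be read, because all four stop at the same limit: the limit of > 50000 nM in this assay, at which 4 of the 4 values shown sit.

The compounds shown leave open how far any of them is from measurable activity, and whether the halogen on the phenyl ring matters at all.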